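Aryl replacement on the shared core: compound 3 to compound 4

A few compounds are considered here, and "the series" means these few. Any claim that something is new, unique, unknown or untested is made for them only; others in the source may bear on it.

The three measured compounds share one core and differ only in the aromatic group on the five-membered ring. Compound 1 `O=C(O)Cc1sc(C(c2ccc(F)cc2)c2ccc(F)cc2)nc1-c1cc(F)cc(F)c1` carries a 3,5-difluorophenyl there, and in an in vitro assay on HEK385-7 cells for displacement of a labelled ligand from prostaglandin D2 receptor 2 (Homo sapiens) (on this read-out higher numbers stand for weaker inhibition and lower numbers for stronger inhibition), compound 1 gives 35 nM. Compound 2 `COc1cc(-c2nc(C(c3ccc(F)cc3)c3ccc(F)cc3)sc2CC(=O)O)ccn1` carries a 2-methoxypyridin-4-yl and gives 29 nM. Compound 3 `CS(=O)(=O)Nc1cccc(-c2nc(C(c3ccc(F)cc3)c3ccc(F)cc3)sc2CC(=O)O)c1` carries a 3-(methanesulfonamido)phenyl and gives 40 nM. Compound 3 returns the highest of the three numbers, but every gap is within the scatter: a 1.1-fold higher number from compound 1 to compound 3 (0.06 log units; within the scatter) and a 1.4-fold higher number from compound 2 to compound 3 (0.14 log units; within the scatter), and likewise a 1.2-fold lower number from compound 1 to compound 2 (0.08 log units; within the scatter).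

Compound 4 `O=C(O)Cc1sc(C(c2ccc(F)cc2)c2ccc(F)cc2)nc1-c1ccnc(O)c1` continues the same exercise at the same place: 2-hydroxypyridin-4-yl in place of 3-(methanesulfonamido)phenyl on an aromatic carbon. All three measured steps bear on it, since each exchanges the whole aromatic group at this position, and none of them moved the number beyond the scatter. Neither a phenyl with two fluorines, a pyridine bearing a methoxy group, nor a phenyl bearing a methanesulfonamide changed the read-out in any direction. On that basis no step beyond the scatter is expected from compound 3 to compound 4; the estimated step is a 1.2-fold lower number from compound 3 to compound 4 (0.08 log units; within the scatter). Compound 4 is therefore expected to give about 33 nM, with a range of 12 nM to 90 nM.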

Compound 4, half-maximal inhibitory concentration: 68 nM
For compound 4 the middle estimate is 2.1-fold (0.31 log units) below the measured one; the range from low to high includes it.
By their numbers in this assay, from the lowest: compounds 2, 1, 3 and 4 (each within the scatter of the next, the first and the last beyond it).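

Working notes on this position: in this assay, a change as small as hydrogen in place of methyl on the oxygen of the 2-methoxypyridin-4-yl group gives the first step beyond the scatter at this position, a 2.3-fold higher number from compound 2 to compound 4 (0.37 log units; beyond the scatter), and that step is modest. The other two exchanges, a 1.7-fold higher number from compound 3 to compound 4 (0.23 log units; within the scatter) and a 1.9-fold higher number from compound 1 to compound 4 (0.29 log units; within the scatter), remain within the scatter, so among the groups shown the 2-hydroxypyridin-4-yl group is set apart only from the 2-methoxypyridin-4-yl group. The position therefore tolerates whole-group exchanges among these aryl groups without a step beyond the scatter, yet it registers the loss of this one methyl, and no measurement at hand gives a reason for that step.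

Open, on these data alone, is how an amine or an ethoxy group in place of the hydroxy on the same pyridine would read in this assay. Also open, as far as these compounds go, is whether a methoxyphenyl and its hydroxyphenyl counterpart at this position would show a step of similar size, or whether this step holds only for the pyridine pair of compound 2 and compound 4.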